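From 3-iodophenyl to thiophen-2-yl in the series

The source may report more compounds than this note shows. Statements on the series, on what has been measured and on what is new or still open speak of the compounds shown alone.

In a functional assay on Hs 683 cells (Homo sapiens) for cytotoxicity, read by MTT assay (a higher number here means a weaker inhibitor, a lower number a stronger inhibitor), compound 3 `Oc1ccc(CN(Cc2cccc(I)c2)Cc2ccc(O)c3ncccc23)c2cccnc12` gives 479 nM and is the weakest of the three measured compounds. Compound 1 `Oc1ccc(CN(Cc2ccccc2C(F)(F)F)Cc2ccc(O)c3ncccc23)c2cccnc12` gives 64 nM and compound 2 `Oc1ccc(CN(Cc2cccc(C(F)(F)F)c2)Cc2ccc(O)c3ncccc23)c2cccnc12` gives 36 nM in the same read-out. Compound 4 `Oc1ccc(CN(Cc2cccs2)Cc2ccc(O)c3ncccc23)c2cccnc12` has thiophen-2-yl in place of 3-iodophenyl on a saturated chain carbon bound to an amine nitrogen and remains unmeasured.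

For the measured compounds named here, no measured compound carries thiophen-2-yl, so the evidence is indirect. Going by the values given here, three steps bear on the change: a 1.8-fold lower number from compound 1 to compound 2 (0.25 log units; within the scatter) stays within the scatter, a 7.5-fold higher number from compound 1 to compound 3 (0.87 log units; beyond the scatter) is modest, and a 13-fold higher number from compound 2 to compound 3 (1.12 log units; beyond the scatter) is large. Changing this group can therefore shift the number substantially, although the step between compound 1 and compound 2 does not. With compound 3 at the high end at 479 nM a move toward a lower number is expected, but probably less than the large step. In this assay the estimated step is a 2.7-fold lower number from compound 3 to compound 4 (0.43 log units; beyond the scatter) and remains quite uncertain. Compound 4 is estimated at 180 nM (expected range 50 nM to 650 nM).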

Compound 4, half-maximal inhibitory concentration: 35 nM
Estimate against measurement, compound 4: 5.1-fold (0.71 log units) above, outside the stated range (below it).
By their numbers in this assay, from the lowest: compounds 4, 2 and 1 (each within the scatter of the next); then compound 3.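

In this assay, thiophen-2-yl in place of 3-iodophenyl gives a 14-fold lower number from compound 3 to compound 4 (1.14 log units; beyond the scatter), so a five-membered aromatic ring with 1 hetero atom is accepted on a saturated chain carbon bound to an amine nitrogen, and a six-membered aromatic ring of carbon only is not required there. Against the two trifluoromethyl compounds, the change reads a 1.0-fold lower number from compound 2 to compound 4 (0.01 log units; within the scatter) and a 1.8-fold lower number from compound 1 to compound 4 (0.26 log units; within the scatter), which leaves compound 3 as the only one of the four set apart from the rest. Nothing on hand accounts for that separation.

The compounds shown leave open whether the gain comes from losing the iodo group or from the thiophene ring itself, as they include no plain phenyl. Also open, on these data alone, is whether furan-2-yl or pyridin-2-yl would read like thiophen-2-yl.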